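Trimming Isopropyl to Ethyl on the Shared Core

This account rests on a few compounds, and the source may have more. Where it says the series, first, only, none or still open, it means among the compounds named here.

In a functional assay on MT2 cells (Homo sapiens) for cytotoxicity (a lower number here means that less compound is tolerated, a higher number that more compound is tolerated), compound 3 `CC(C)=CCOc1cc(Nc2nccs2)ccc1C(C)C` gives 31000 nM and sits level with compound 1 `CCCc1ccc(Nc2nccs2)cc1OCC=C(C)C` at 23000 nM. Compound 2 `CC(C)=CCOc1cc(Nc2nccs2)ccc1C#N` stands apart at 500 nM, and a 62-fold higher number from compound 2 to compound 3 (1.79 log units; beyond the scatter) is large. Compound 4 `CCc1ccc(Nc2nccs2)cc1OCC=C(C)C` differs from compound 3 by hydrogen in place of methyl on a saturated chain carbon bound to an aromatic carbon and a saturated chain carbon and carries hydrogen in place of methyl on a saturated chain carbon bound to an aromatic carbon and a saturated chain carbon, so isopropyl becomes ethyl. The large 46-fold lower number from compound 1 to compound 2 (1.66 log units; beyond the scatter) involved cyano, which is absent here. The closer precedent, isopropyl in place of propyl, gave only a 1.3-fold higher number from compound 1 to compound 3 (0.13 log units; within the scatter) and stayed within the scatter. The expected change is therefore small, an estimated 1.2-fold lower number from compound 3 to compound 4 (0.08 log units; within the scatter) and no more than scatter. Compound 4 is expected at 26000 nM, with an estimated range from 11000 nM to 55000 nM in this measurement.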

Compound 4, half-maximal cytotoxic concentration: 31000 nM
For compound 4 the middle estimate is 1.2-fold (0.08 log units) below the measured one; the measured number falls inside the stated range.
By their numbers in this assay, from the lowest: compound 2; then compounds 1, 3 and 4 (each within the scatter of the next).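

In this assay, trimming isopropyl to ethyl leaves the number unmoved, with no change at the digits printed from compound 3 to compound 4 (within the scatter) and, on the propyl side, a 1.3-fold higher number from compound 1 to compound 4 (0.13 log units; within the scatter) as well. Ethyl, propyl and isopropyl on this aromatic carbon therefore read alike, and cyano is the one group of the four that goes against this, as a 62-fold higher number from compound 2 to compound 4 (1.79 log units; beyond the scatter) shows. No evidence here explains this flat response or the cyano gap. Going by these compounds, whether an amine, a carboxylic acid or a longer chain such as hexyl on this carbon would stay level with the small alkyl groups or shift like cyano remains open.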